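The source may report more compounds than this note shows. Statements on the series, on what has been measured and on what is new or still open speak of the compounds shown alone.

Of the compounds shown here, three built on one shared core have been tested in an ADME assay on PC-3 cells (Homo sapiens) for cytotoxicity, read by WST assay, tested at 100 uM; on this read-out lower numbers stand for less inhibition and higher numbers for more inhibition at the one concentration tested (going by the name of the read-out). Compound 1, `O=C(Nc1ccc(Cl)cc1)C1CCCN(C(=O)c2cccc(-c3nccs3)c2)C1`, carries a 1,3-thiazol-2-yl group on an aromatic carbon and gives 32%. Compound 2, `Cc1nc(-c2cccc(C(=O)N3CCCC(C(=O)Nc4ccc(Cl)cc4)C3)c2)no1`, gives 0%, and compound 3, `COC(=O)c1cccc(C(=O)N2CCCC(C(=O)Nc3ccc(Cl)cc3)C2)c1`, gives 0%. Compound 3 thus sits level with compound 2, and both stand clearly under compound 1: the step of a number 32 percentage points lower from compound 1 to compound 3 (beyond the scatter), and the step of a number 32 percentage points lower from compound 1 to compound 2 (beyond the scatter), while the step of no change at the digits printed from compound 2 to compound 3 (within the scatter).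

Compound 4, `CS(=O)(=O)Nc1cccc(C(=O)N2CCCC(C(=O)Nc3ccc(Cl)cc3)C2)c1`, is the next variation on this core. Its change from compound 3 is methanesulfonamido in place of methoxycarbonyl on an aromatic carbon.

Two of the measured steps bear on this. Removing the 1,3-thiazol-2-yl group gave a large drop, whichever group took its place, and the exchange of one such replacement for another, from compound 2 to compound 3, gave nothing beyond the scatter. Methanesulfonamido has not itself been tested, but a swap between two non-thiazole groups has so far left the number where it was. The expectation for compound 4 in this assay is therefore a step of a number 5 percentage points higher from compound 3 to compound 4 (within the scatter), that is, none beyond the scatter. Compound 4 is estimated at 5%, with a likely range from 0% to 25%.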

Compound 4, a percentage reported as inhibition, at one concentration (the size of the read-out at that concentration, not a potency): 3%
For compound 4 the middle estimate is 2 percentage points above the measured one, and the stated range covers the measured number.
By their numbers in this assay, from the lowest: compounds 2, 3 and 4 (each within the scatter of the next); then compound 1.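

In this assay, among these compounds, a third group without the 1,3-thiazol-2-yl ring joins the two tested before it, and it is the first with a hydrogen-bond donor, which methoxycarbonyl lacks: the change gives no step beyond the scatter (a number 3 percentage points higher from compound 3 to compound 4 (within the scatter)), and the same holds against the oxadiazole (a number 3 percentage points higher from compound 2 to compound 4 (within the scatter)). The gap to the thiazole compound remains, though it is modest (a number 29 percentage points lower from compound 1 to compound 4 (beyond the scatter)), so compounds 2, 3 and 4 form one group at this position despite their different atoms, while compound 1 alone stands apart from each of them. The sulfur and nitrogen of methanesulfonamido do not bring back the number seen with the thiazole, and nothing available here explains why that group stands apart.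

Still open, on these data alone, is whether the higher number belongs to the 1,3-thiazol-2-yl group alone, or whether a close relative such as a 2-thienyl or 1,3-oxazol-2-yl group at the same place would share it. Equally open, as far as these compounds go, is whether a simple amine or a carboxylic acid there would stay with compounds 2, 3 and 4.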